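This account rests on a few compounds, and the source may have more. Where it says the series, first, only, none or still open, it means among the compounds named here.

Working notes on the series.

Compound 1 `O=C(NCc1ccccc1)c1cn(-c2ccccc2)nc1-c1cccnc1` is the starting point of this step. Within the data shown here, in a functional assay on HL-60 cells (Homo sapiens) for cytotoxicity, read by MTT assay, with a stated time of 48 h (a higher number here means a weaker inhibitor, a lower number a stronger inhibitor), compound 1 gives "nd(insoluble)" (no result reported), which is no number at all; where it stands in this assay therefore cannot be placed, and no step from it has been measured. Among the measured compounds shown here, the only number so far comes from compound 2 `O=C(c1cn(-c2ccccc2)nc1-c1cccnc1)N1CCC(Cc2ccccc2)CC1`, which shares the core of compound 1 and carries a different group on the carbonyl carbon; in this assay compound 2 gives 16100 nM. For the measured compounds named here, no step between compound 1 and compound 2 is recorded, so their two results show only that one compound gave no number and the other a weak one.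

Compound 3 `COc1ccc(OC(=O)c2cn(-c3ccccc3)nc2-c2cccnc2)cc1` is the unmeasured compound. It differs from compound 1 in one place: 4-methoxyphenoxy in place of benzylamino on a carbonyl carbon. With no number for compound 1, the size of the step cannot be computed, and no direction can be read from the data; the expectation rests on compound 2 alone. Compound 3 is expected to give about 20000 nM in this assay, within a range of 5000 nM to 80000 nM, with a real chance that no number is obtained.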

Compound 3, half-maximal inhibitory concentration: > 100000 nM
Compound 3 ended at the assay's limit; the forecaster's own chance of this, stated with the estimate: 35%; middle value at least 5.0-fold (0.69 log units) from the limit.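

In this assay compound 3 gives > 100000 nM, which is a limit of the assay and not a number. Among these compounds, with compound 1 at "nd(insoluble)" (no result reported), no step to compound 3 can be read. The compounds shown leave open how far 4-methoxyphenoxy in place of benzylamino on a carbonyl carbon changes the result in this assay.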